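Growth inhibition series: fluoro to methyl

A few compounds are considered here, and "the series" means these few. Any claim that something is new, unique, unknown or untested is made for them only; others in the source may bear on it.

Measured in a functional assay on 786-0 cells (Homo sapiens) for inhibition, read by sulforhodamine B assay, with a stated time of 48 h; on this read-out lower numbers stand for stronger inhibition of growth and higher numbers for weaker inhibition of growth:
- compound 1 `CCOC(=O)c1nn(-c2ccccc2)c(-c2ccc(F)cc2)c1CNC(C)(C)C`: > 632000 nM; 319000 nM (2 entries)
- compound 2 `CCOC(=O)c1nn(-c2ccc(Cl)cc2)c(-c2ccc(F)cc2)c1CNC(C)(C)C`: > 582000 nM; > 537000 nM (2 entries) (limits only)
- compound 3 `CC(C)(C)NCc1c(C(=O)O)nn(-c2ccccc2)c1-c1ccc(F)cc1`: > 680000 nM (a limit)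

Compound 3 has no numerical value on this read-out, only the limit > 680000 nM. Compound 1 has one limit and one number among its entries (the several entries of compound 1 in this assay, > 632000 nM; 319000 nM (2 entries)). Compound 2 has limits alone (the several entries of compound 2 in this assay, > 582000 nM; > 537000 nM (2 entries)). Within the data shown here, no measured pair in this set differs in one place, so no measured step is available as a guide.

Compound 4 `Cc1ccc(-c2c(CNC(C)(C)C)c(C(=O)O)nn2-c2ccccc2)cc1` differs from compound 3 by methyl in place of fluoro on an aromatic carbon, para to a large group (methyl in place of fluoro on an aromatic carbon). The same difference reads 4-fluorophenyl to 4-methylphenyl.

In this assay, no step beyond the usual scatter is expected, and neither direction is favoured. The expected step of an at least 1.3-fold lower number from compound 3 to compound 4 (0.13 log units; that floor lies within the scatter) is an estimate only. This expectation rests on compound 3, whose limit is > 680000 nM, and a limit is also the likely report for compound 4. For compound 4 the estimated value is 500000 nM, with an expected range from 200000 nM to 900000 nM.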

Compound 4, concentration for 50% growth inhibition: > 688000 nM
Compound 4 gave a limit, no number; the forecaster's own chance of this, stated with the estimate: 70%; at least 1.3-fold (0.13 log units) between middle value and limit.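

In this assay compound 3 reads > 680000 nM, a limit. Compound 4 reads > 688000 nM, also a limit, so no step can be read between these two compounds. The compounds shown leave open whether methyl in place of fluoro changes growth inhibition at all.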